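The compounds below may be only part of what the source reports. "The series", "measured", "known", "first", "only" and "open" are said of these compounds alone.

Measured compounds:
Compound 1 `COc1ccc(-c2cc(/C=C/C(=O)c3ccc(OC)c(OC)c3)[nH]n2)cc1` gives 24800 nM in a functional assay on NCI/ADR-RES cells (Homo sapiens) for inhibition, read by sulforhodamine B assay, with a stated time of 48 h; a higher number here means a weaker inhibitor of growth, a lower number a stronger inhibitor of growth.
Compound 2 `COc1cc(-c2cc(/C=C/C(=O)c3ccc(Cl)c(Cl)c3)[nH]n2)cc(OC)c1OC` gives > 100000 nM in this assay.
Compound 3 `COc1ccc(-c2cc(/C=C/C(=O)c3ccc(N)cc3)[nH]n2)cc1` gives 15500 nM in this assay.

Compound 2 stands apart from the other two: its result is a limit of the assay and not a number, as the limit of > 100000 nM in this assay, at which 1 of the 3 values shown sits, shows, so its growth inhibition was too weak to be pinned down. Compound 1 and compound 3 each gave a real number.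

The compound not yet measured is compound 4 `COc1ccc(C(=O)/C=C/c2cc(-c3cc(OC)c(OC)c(OC)c3)n[nH]2)cc1OC`. It differs from compound 2 in one place: 3,4-dimethoxyphenyl in place of 3,4-dichlorophenyl on a carbonyl carbon. Compound 1 also carries a 3,4-dimethoxyphenyl on a carbonyl carbon and gave a measurable value, whereas compound 2 with its 3,4-dichlorophenyl did not. Compound 4 is therefore expected to be a stronger inhibitor of growth than compound 2, with the step of an at least 3.3-fold lower number from compound 2 to compound 4 (0.52 log units; beyond the scatter) expected to run well beyond the scatter toward lower numbers, though it may remain a limit. Compound 4 is estimated at 30000 nM, within a range from 12000 nM to 80000 nM.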

Compound 4, concentration for total growth inhibition: 15700 nM
Compound 4: the middle estimate sits 1.9-fold (0.28 log units) above what was measured; the range from low to high includes it.
By their numbers in this assay, from the lowest: compounds 3, 4 and 1 (each within the scatter of the next). At a limit, above all of these: compound 2.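

For the compounds shown here, compound 2 and compound 4 differ in one place only, so this pair gives the first direct reading of a change on a carbonyl carbon, with the rest of the molecule held fixed. Putting 3,4-dimethoxyphenyl in place of 3,4-dichlorophenyl gives in this assay an at least 6.3-fold lower number from compound 2 to compound 4 (0.80 log units; beyond the scatter), which shows that the group at this place alone can move a compound from no measurable value to a real number. The result for compound 2 is a limit of the assay and not a number, so this step gives only a minimum size: the limit of > 100000 nM in this assay, at which 1 of the 4 values shown sits.

From the compounds shown here alone, it remains open whether a plain phenyl or a 3,4-dihydroxyphenyl at this place would give a similar number. The compounds shown also leave open whether the same change would have a similar effect on the core of compound 1.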